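Cell tolerance after a ring swap on compound 3

A few compounds are considered here, and "the series" means these few. Any claim that something is new, unique, unknown or untested is made for them only; others in the source may bear on it.

compound 1 `O=S(=O)(Cc1nc(-c2ccnc(Cl)c2)c2sccc2n1)c1cccc(Cl)c1` gives 63000 nM
compound 2 `O=S(=O)(Cc1nc(-c2ccc(F)nc2)c2sccc2n1)c1cccc(Cl)c1` gives 40000 nM
compound 3 `O=c1ccc(-c2nc(CS(=O)(=O)c3cccc(Cl)c3)nc3ccsc23)c[nH]1` gives > 50000 nM (a limit, not a number)

These values come from an ADME assay on cells (Homo sapiens) for cytotoxicity, read by resazurin assay, with a stated time of 5 days (a higher number here means that more compound is tolerated, a lower number that less compound is tolerated), and all sit high on its scale. In this assay compound 3 stands at > 50000 nM and this is a limit of the assay. Compound 4 `O=S(=O)(Cc1nc(-c2ccoc2)c2sccc2n1)c1cccc(Cl)c1` differs from compound 3 in one group on an aromatic carbon: a group of 5 heavy atoms (4 carbon, 1 oxygen; one five-membered aromatic ring with 1 hetero atom) in place of a group of 7 heavy atoms (5 carbon, 1 nitrogen, 1 oxygen; one six-membered aromatic ring with 1 hetero atom), on an aromatic carbon and the group that enters is furan-3-yl.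

Three measured swaps of the group at this place bear on the question. The first is a 1.6-fold lower number from compound 1 to compound 2 (0.20 log units; within the scatter) and the second is an at least 1.2-fold higher number from compound 2 to compound 3 (0.09 log units; that floor lies within the scatter) while the third is a step that the limit leaves unreadable from compound 1 to compound 3 and so gives no size. All of these swaps involve six-membered rings, so none of them tests a five-membered ring directly. No clear direction can be drawn from them, and the expectation is for no change beyond the scatter. The estimate means an at least 1.1-fold lower number from compound 3 to compound 4 (0.04 log units; that floor lies within the scatter) as the expected step. Compound 4 is expected to give about 45000 nM in this assay, with an estimated range from 20000 nM to 90000 nM.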

Compound 4, half-maximal cytotoxic concentration: > 50000 nM
Compound 4: only a limit was reported (the forecaster's own chance of this, stated with the estimate: 35%); middle value at least 1.1-fold (0.04 log units) from the limit.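

Furan-3-yl is the first five-membered aromatic ring shown at this place, and in this assay compound 4 gives > 50000 nM, which is a limit and not a number. Among the compounds shown here, the only step that can be read is an at least 1.2-fold higher number from compound 2 to compound 4 (0.09 log units; that floor lies within the scatter), so the swap from a six-membered ring to this five-membered ring, which has 0 hydrogen-bond donors, shows no change beyond the scatter. The steps to compound 4 from compound 1 and from compound 3 cannot be read because of the limit: the limit of > 50000 nM in this assay, at which 2 of the 4 values shown sit.

On these data alone, the true values of compound 3 and compound 4 remain unknown, so no order between them can be given. As far as these compounds go, it also remains open how cells would tolerate a non-aromatic group at this place, such as an amine or a carboxylic acid.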